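Swapping the aryl ketone for a pyridin-2-yl ketone

This account rests on a few compounds, and the source may have more. Where it says the series, first, only, none or still open, it means among the compounds named here.

Three analogues of one shared core have been measured in a functional assay on SK-BR-3 cells (Homo sapiens) for antiproliferative activity, read by XTT assay, with a stated time of 72 h; on this read-out lower numbers stand for stronger inhibition and higher numbers for weaker inhibition. Compound 1 `COc1ccc(-c2cc3ccccc3nc2/C=C/C(=O)c2ccc(OC)cc2OC)cc1` gives 2260 nM, compound 2 `COc1ccc(-c2cc3ccccc3nc2/C=C/C(=O)c2ccc(OC)c(OC)c2)cc1` gives 3260 nM, and compound 3 `COc1ccc(-c2cc3ccccc3nc2/C=C/C(=O)c2ccc(N)cc2)cc1` gives 8560 nM. Compound 3 therefore stands at the highest number of the three: the step of a 3.8-fold higher number from compound 1 to compound 3 (0.58 log units; beyond the scatter) and the step of a 2.6-fold higher number from compound 2 to compound 3 (0.42 log units; beyond the scatter) both lie beyond the scatter, while the step of a 1.4-fold higher number from compound 1 to compound 2 (0.16 log units; within the scatter) does not. The unmeasured compound 4 `COc1ccc(-c2cc3ccccc3nc2/C=C/C(=O)c2ccccn2)cc1` differs from compound 3 by pyridin-2-yl in place of 4-aminophenyl on a carbonyl carbon. The two measured steps that touch the same carbonyl carbon show that changing the aryl group there can move the number by a modest amount, but neither involves a pyridin-2-yl group, so the direction for compound 4 is uncertain. Because compound 3 sits at 8560 nM, compound 4 is expected to land near it, with a step of about a 1.2-fold lower number from compound 3 to compound 4 (0.09 log units; within the scatter). The estimate for compound 4 in this assay is 7000 nM, with a range from 2500 nM to 20000 nM.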

Compound 4, half-maximal inhibitory concentration: 370 nM
Compound 4: middle estimate off by 19-fold (1.28 log units), on the high side, and the stated range ends above it.
By their numbers in this assay, from the lowest: compound 4; then compounds 1 and 2 (each within the scatter of the next); then compound 3.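

In this assay, within the data shown here, the group on the carbonyl carbon proves able to move the number much further than the earlier steps showed, with pyridin-2-yl in place of 4-aminophenyl giving a large change (a 23-fold lower number from compound 3 to compound 4 (1.36 log units; beyond the scatter)). The gain also holds against both dimethoxyphenyl groups (an 8.8-fold lower number from compound 2 to compound 4 (0.95 log units; beyond the scatter); a 6.1-fold lower number from compound 1 to compound 4 (0.79 log units; beyond the scatter)), so compound 4, the only one of the four with a nitrogen in the ring on the carbonyl carbon, has the lowest number, with all its steps beyond the scatter. No measurement shown here accounts for this change.

From the compounds shown here alone, what stays open is whether a plain phenyl, pyridin-3-yl or pyridin-4-yl group on the carbonyl carbon would give a number like that of compound 4. Going by these compounds, it is equally open whether a methyl, methoxy or amine on the pyridin-2-yl ring would keep that number.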